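A Nitro Group in Place of Tert-Butyl on the Aryl Ring

The source may hold more compounds than are shown below. What is called first, only, known or untested is meant among the compounds shown, and "the series" means these compounds.

Two carbamates of this series have been tested in a functional assay on the whole organism for inhibition, with Mus musculus as the target, in the writhing test, with a stated time of 1 h, at a dose of 10 mg/kg by the oral route; a lower number here means less inhibition, a higher number more inhibition at the dose given (going by the name of the read-out). Compound 1 `Cc1ccc(N2CCN(CCC(OC(N)=O)c3ccccc3)CC2)c(C)c1` gives 34% in this assay. For the measured compounds named here, compound 2 `CC(C)(C)c1ccc(C(CCN2CCN(c3ccccc3)CC2)OC(N)=O)cc1` gives 62% in this assay, the higher of the two numbers; its only neighbour, compound 1, sits well below it, and that gap is beyond the usual scatter of repeated measurements. Going by the values given here, the two compounds differ in more than one place, so their two values show only that the inhibition of compound 2 in this assay is the higher of the pair at the dose tested.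

Compound 3 `NC(=O)OC(CCN1CCN(c2ccccc2)CC1)c1ccc([N+](=O)[O-])cc1` has not yet been measured. It differs from compound 2 in one place: nitro in place of tert-butyl on an aromatic carbon. Among the compounds with values here, no pair of measured compounds differs by such an exchange, and the data say nothing about what it does to the read-out. Given that, a step of modest size downward, or none beyond the scatter, is expected; the estimated step is a number 12 percentage points lower from compound 2 to compound 3 (beyond the scatter). For compound 3 the inhibition expected in this assay is 50%, with a range from 25% to 75%.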

Compound 3, a percentage reported as inhibition, in the whole organism at one dose (the size of the read-out at that dose, not a potency): 91.2%
Compound 3: middle estimate off by 41.2 percentage points, on the low side; measured number outside the range, above it.
By their numbers in this assay, from the lowest: compound 1; then compound 2; then compound 3.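

For the compounds shown here, the exchange of tert-butyl for nitro on an aromatic carbon, para to a large group, is the first change in one place that can be read, and in this assay it gives a number 29.2 percentage points higher from compound 2 to compound 3 (beyond the scatter). This shows that the group at this position of the ring matters to the read-out at the dose tested: compound 2 already stood high among the compounds shown, and the exchange, which removes four carbons and brings in a nitrogen and two oxygens, carries inhibition further still. Nothing measured here accounts for the size of this step, and its origin remains unexplained.

One exchange cannot separate what nitro adds from what the loss of tert-butyl removes, and the compounds shown include no amine, nitrile or carboxylic acid at this place to test how far the result extends to other groups. Also open, going by these compounds, is whether the step would hold at other doses or on the core of compound 1, since each compound is described here by a single number at one dose.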